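The source may report more compounds than this note shows. Statements on the series, on what has been measured and on what is new or still open speak of the compounds shown alone.

Measured compounds:
compound 1 `Cc1ccc2nc(C(=O)Nc3c(F)cc(-c4cccc(F)c4)cc3F)c(C)c(O)c2c1`: 5.25%
compound 2 `CCc1ccc2nc(C(=O)Nc3c(F)cc(-c4cccc(F)c4)cc3F)c(C)c(O)c2c1`: 16.2%

In a functional assay on Hep 3B2 cells (Homo sapiens) for antiproliferative activity, read by MTT assay, with a stated time of 24 h, tested at 0.41 ug/mL (a higher number here means a stronger effect of the compound at the concentration tested, a lower number a weaker effect), compound 1 gives 5.25% and compound 2 gives 16.2%. For the measured compounds named here, compound 2 stands highest of the two numbers, and its nearest neighbour is compound 1, with the only measured step being a number 11 percentage points higher from compound 1 to compound 2 (beyond the scatter). Compound 3 `Cc1c(C(=O)Nc2c(F)cc(-c3cccc(F)c3)cc2F)nc2ccc(F)cc2c1O` is the next step from compound 2: fluoro in place of ethyl on an aromatic carbon. Going by the values given here, the one step that bears on this change, a number 11 percentage points higher from compound 1 to compound 2 (beyond the scatter), went with a longer saturated chain at this place of the shared core and gave a higher number; compound 3 carries no chain there at all, and no measured compound carries fluoro at this place. The expectation for compound 3 is therefore a fall back toward the level of compound 1, a step of a number 8.2 percentage points lower from compound 2 to compound 3 (within the scatter) in this assay. The estimated value for compound 3 is 8%, with a range from 0% to 20%.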

Compound 3, a percentage reported as inhibition, at one concentration (the size of the read-out at that concentration, not a potency): 4.85%
The estimate for compound 3 lay 3.2 percentage points above the measured number, within the range that was stated.
By their numbers in this assay, from the lowest: compounds 3 and 1 (each within the scatter of the next); then compound 2.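

In this assay, the swap to fluoro on this aromatic carbon gives a number 11.4 percentage points lower from compound 2 to compound 3 (beyond the scatter), so the gain seen with ethyl does not survive when the chain is removed. Fluoro and methyl at this place give a number 0.4 percentage points lower from compound 1 to compound 3 (within the scatter), which means that the two groups cannot be told apart here and that, among the three compounds, only the ethyl of compound 2 stands out. Nothing measured here explains this pattern.

From the compounds shown here alone, what remains open is whether the number keeps rising with a longer chain, such as propyl or butyl, or whether ethyl is already the best fit at this place. It is also unclear how an oxygen or nitrogen group, such as methoxy or an amine, would behave on this aromatic carbon.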